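Compound 3: hydroxy replacing trifluoromethyl

The source may report more compounds than this note shows. Statements on the series, on what has been measured and on what is new or still open speak of the compounds shown alone.

Measured so far in a functional assay on SW-620 cells (Homo sapiens) for inhibition, read by MTT assay, with a stated time of 72 h; a lower number here means a stronger inhibitor, a higher number a weaker inhibitor:
- compound 1 `COc1cc(NC(C)CCCNC(=O)Nc2ccc(Br)cc2)c2ncccc2c1` gives 23000 nM
- compound 2 `COc1cc(NC(C)CCCNC(=O)Nc2ccc(C(F)(F)F)cc2)c2ncccc2c1` gives 22000 nM

Compound 2 stands level with compound 1 on these numbers, with the gap between them lying within the scatter. The change to compound 3 `COc1cc(NC(C)CCCNC(=O)Nc2ccc(O)cc2)c2ncccc2c1` is hydroxy in place of trifluoromethyl on an aromatic carbon, para to a large group (hydroxy in place of trifluoromethyl on an aromatic carbon). Within the data shown here, the only measured step at this place is a 1.0-fold lower number from compound 1 to compound 2 (0.02 log units; within the scatter) for trifluoromethyl in place of bromo, and it lies within the scatter. Among the measured compounds shown here, no measured compound carries hydroxy, so this single step gives thin support. In this assay, from the compounds shown here alone, no step beyond the scatter is expected, and the direction stays open. The estimated step is a 1.1-fold higher number from compound 2 to compound 3 (0.06 log units; within the scatter) in size. For compound 3 the expected value is 25000 nM with an estimated range of 10000 nM to 60000 nM as the wide margin.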

Compound 3, half-maximal inhibitory concentration: 30000 nM
Compound 3: the middle estimate sits 1.2-fold (0.08 log units) below what was measured; low and high end bracket the measured number.
By their numbers in this assay, from the lowest: compounds 2, 1 and 3 (each within the scatter of the next).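

In this assay, hydroxy on an aromatic carbon para to a large group gives a 1.4-fold higher number from compound 2 to compound 3 (0.13 log units; within the scatter) and a 1.3-fold higher number from compound 1 to compound 3 (0.12 log units; within the scatter), so neither step separates it from the earlier groups. Exchanging trifluoromethyl, with its 4 heavy atoms and 0 hydrogen-bond donors, for hydroxy, with 1 heavy atom and 1 hydrogen-bond donor, therefore brings no step beyond the scatter, and bromo, trifluoromethyl and hydroxy cannot be told apart here. No evidence is available to account for these numbers.

From the compounds shown here alone, whether an amine or a carboxylic acid at this place would give a step beyond the scatter remains open. Also open, going by these compounds, is whether a longer chain in place of the one on the shared core would change the reading in this assay.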